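A few compounds are considered here, and "the series" means these few. Any claim that something is new, unique, unknown or untested is made for them only; others in the source may bear on it.

Compound 1, `Cc1ccc(S(=O)(=O)c2nc3ccccc3nc2Nc2ccccc2)cc1`: in a functional assay on PC-3 cells (Homo sapiens) for cytotoxicity, read by MTT assay, with a stated time of 72 h (on this read-out lower numbers stand for stronger inhibition and higher numbers for weaker inhibition), compound 1 gives 1060 nM.
Compound 2, `COc1ccc(S(=O)(=O)c2nc3ccccc3nc2Nc2ccccc2)cc1`: in this assay compound 2 gives 1260 nM.
Compound 3, `O=S(=O)(c1ccc(Br)cc1)c1nc2ccccc2nc1Nc1ccccc1`: in this assay compound 3 gives 1180 nM.

Compound 3 sits between the other two, but only barely: the step of a 1.1-fold higher number from compound 1 to compound 3 (0.05 log units; within the scatter) and the step of a 1.1-fold lower number from compound 2 to compound 3 (0.03 log units; within the scatter) both lie within the scatter, as does a 1.2-fold higher number from compound 1 to compound 2 (0.08 log units; within the scatter), so the three measured compounds cannot be ordered on these numbers.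

Compound 4, `O=S(=O)(c1ccc(Br)cc1)c1nc2ccccc2nc1Nc1cccc(O)c1`, differs from compound 3 by hydroxy in place of hydrogen on an aromatic carbon. Going by the values given here, no measured step bears directly on this change: each of the three steps swaps one group on a different ring of the shared core, and each of them stayed within the scatter. Among the compounds with values here, the only guidance is that small substituent swaps elsewhere on this core left this assay essentially unchanged. The step of a 1.2-fold lower number from compound 3 to compound 4 (0.07 log units; within the scatter) is therefore expected to stay within the scatter. For compound 4 the estimated value in this assay is 1000 nM, with a range from 400 nM to 2500 nM.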

Compound 4, half-maximal inhibitory concentration: 1700 nM
Beside the measured number, compound 4's estimate is 1.7-fold (0.23 log units) below it; low and high end bracket the measured number.
By their numbers in this assay, from the lowest: compounds 1, 3, 2 and 4 (each within the scatter of the next).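

In this assay, going by these compounds alone, the step of a 1.4-fold higher number from compound 3 to compound 4 (0.16 log units; within the scatter) gives the first reading from the anilino part of the shared core, since the earlier steps each swapped one group on a different ring. Here, hydroxy replaces hydrogen on an aromatic carbon, meta to a large group, and so adds a group with one hydrogen-bond donor and one hydrogen-bond acceptor. The step stays within the scatter, so this single added oxygen makes no readable difference at this place on the phenyl ring, and the result extends the flat picture seen so far to a second part of the molecule.

Going by these compounds, whether a larger or charged group, such as an amine or a carboxylic acid, would be tolerated at this same place remains open. No measurement shown accounts for this result.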